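The source may hold more compounds than are shown below. What is called first, only, known or untested is meant among the compounds shown, and "the series" means these compounds.

Compound 3 `CN(C)C1=Nc2ccccc2C(CC(=O)NCc2ccc(N)cc2)N1c1ccccc1` has been tested in a functional assay on DU-145 cells (Homo sapiens) for inhibition, read by sulforhodamine B assay, with a stated time of 72 h (on this read-out lower numbers stand for stronger inhibition of growth and higher numbers for weaker inhibition of growth), and there compound 3 gives > 100000 nM, which is a limit of the assay rather than a number. Among the measured compounds shown here, it is the one of the three values that sits at the limit of > 100000 nM in this assay, at which 1 of the 3 values shown sits. For comparison, compound 1 `O=C(CC1c2ccccc2N=C(N2CCCCC2)N1c1ccccc1)NCc1ccc(NS(=O)(=O)c2ccc(F)cc2)cc1` gives 1710 nM, and compound 2 `CCN1C(N2CCCCC2)=Nc2ccccc2C1CC(=O)NCc1ccc(NS(=O)(=O)c2ccc(F)cc2)cc1` gives 17200 nM; the step of a 10-fold higher number from compound 1 to compound 2 (1.00 log units; beyond the scatter) concerns a different part of the molecule and does not touch the change considered here. Compound 4 `CN(C)C1=Nc2ccccc2C(CC(=O)NCc2ccc([N+](=O)[O-])cc2)N1c1ccccc1` differs from compound 3 by nitro in place of amino on an aromatic carbon. For the measured compounds named here, no measured step covers this change, so the only anchor is the limit of compound 3. Compound 4 is therefore expected to stay at that limit as well, with an estimate of 100000 nM, between 30000 nM and 300000 nM. The expected step from the limit of compound 3 is a number no higher from compound 3 to compound 4 (the limit leaves the size open).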

Compound 4, concentration for 50% growth inhibition: > 100000 nM
Compound 4 ended at the assay's limit (the forecaster's own chance of this, stated with the estimate: 65%); the middle value lies on the limit itself.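

No step from compound 3 to compound 4 can be read in this assay, since each compound gives only a limit of the assay: the limit of > 100000 nM in this assay, at which 2 of the 4 values shown sit.

The compounds shown leave open whether amino or nitro at this place gives stronger inhibition of growth.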